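Swapping a fluorophenyl group for a thiophene ring

The source may hold more compounds than are shown below. What is called first, only, known or untested is meant among the compounds shown, and "the series" means these compounds.

Three compounds from one series share a core built from two fused rings, and all have been tested in a functional assay on aorta (Rattus norvegicus, strain Wistar) for inhibition; on this read-out higher numbers stand for weaker inhibition and lower numbers for stronger inhibition. Compound 1 `CC1(C)OC(=O)C2(C(=O)O1)C(c1ccc(Cl)cc1)C(c1ccccc1)=NN2c1ccccc1` gives 590000 nM. Compound 2 `CC1(C)OC(=O)C2(C(=O)O1)C(c1ccc(F)cc1)C(c1ccccc1)=NN2c1ccccc1` gives 1470000 nM, the highest of the three numbers and therefore the weakest inhibition seen so far. Compound 3 `CN(C)c1ccc(C2C(c3ccccc3)=NN(c3cccc(Cl)c3)C23C(=O)OC(C)(C)OC3=O)cc1`, which differs from the others in several places, gives 430000 nM.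

Compound 4 `CC1(C)OC(=O)C2(C(=O)O1)C(c1cccs1)C(c1ccccc1)=NN2c1ccccc1` is the next candidate. It differs from compound 2 by thiophen-2-yl in place of 4-fluorophenyl on a saturated ring carbon. Within the data shown here, only one single-point step has been measured: a 2.5-fold higher number from compound 1 to compound 2 (0.40 log units; beyond the scatter). That step changes a substituent on the aromatic ring at the same position, but it does not replace the whole ring, so it bears on the present change only loosely, showing that alterations here move the number modestly. Among the measured compounds shown here, no measured pair tests an exchange of a six-membered ring for a five-membered one.

Compound 4 is therefore expected to remain close to compound 2, with an estimated step of a 1.8-fold lower number from compound 2 to compound 4 (0.26 log units; within the scatter). The estimate for compound 4 in this assay is 800000 nM, within a range from 250000 nM to 2500000 nM.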

Compound 4, half-maximal inhibitory concentration: 585000 nM
The estimate for compound 4 lay 1.4-fold (0.14 log units) above the measured number; low and high end bracket the measured number.
By their numbers in this assay, from the lowest: compounds 3, 4 and 1 (each within the scatter of the next); then compound 2.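

In this assay, the whole ring on this saturated ring carbon can be exchanged, not only the halogen on it: a 2.5-fold lower number from compound 2 to compound 4 (0.40 log units; beyond the scatter). Among these compounds, the earlier compounds showed only that a chloro-to-fluoro swap on the six-membered aromatic ring moves the number, whereas here a five-membered aromatic ring containing sulfur replaces that ring entirely. The comparison with the chloro compound gives a 1.0-fold lower number from compound 1 to compound 4 (0.00 log units; within the scatter), so among these three compounds a six-membered ring at this carbon is not needed to reach the number of compound 1, and only the 4-fluorophenyl group of compound 2 stands apart.

On these data alone, what an amine, a carboxylic acid or a longer carbon chain would do on this saturated ring carbon stays open, as does whether any ring is needed there at all. Nothing available gives a measured reason for these differences.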